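Bromobenzyl amide in the bile acid receptor series

The source may report more compounds than this note shows. Statements on the series, on what has been measured and on what is new or still open speak of the compounds shown alone.

compound 1 `COC(=O)/C=C/c1cccc(N(Cc2ccc(-c3ccc(OC)cc3)cc2)C(=O)C2CCCCC2)c1` — 89 nM
compound 2 `COC(=O)/C=C/c1cccc(N(C)C(=O)C2CCCCC2)c1` — > 1000 nM

In an assay on isolated protein with Bile acid receptor (Homo sapiens) as the target (a lower number here means that less compound is needed, a higher number that more compound is needed for the effect), compound 1 gives 89 nM. As far as these compounds go, compound 2 returns only a limit, > 1000 nM, so it sits at the limit of > 1000 nM in this assay, at which 1 of the 2 values shown sits, and its true value is unknown. Compound 3 `COC(=O)/C=C/c1cccc(N(Cc2ccc(Br)cc2)C(=O)C2CCCCC2)c1` carries 4-bromophenyl in place of hydrogen on a saturated chain carbon bound to an amide-type nitrogen. Among the measured compounds shown here, no measured step separates compound 2 from compound 3. Given that compound 1 with its larger benzyl substituent reaches 89 nM, the step from compound 2 to compound 3 is expected to be a gain beyond the scatter, about an at least 3.3-fold lower number from compound 2 to compound 3 (0.52 log units; beyond the scatter). Compound 3 is estimated at 300 nM, between 100 nM and 1500 nM.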

Compound 3, half-maximal effective concentration: > 1000 nM
Compound 3: a limit, no number; the forecaster's own chance of this, stated with the estimate: 30%; at least 3.3-fold (0.52 log units) between middle value and limit.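

In this assay, bromo in place of 4-methoxyphenyl on an aromatic carbon gives an at least 11-fold higher number from compound 1 to compound 3 (1.05 log units; beyond the scatter). The 4-bromobenzyl group on the amide-type nitrogen is therefore not enough to retain the activity of compound 1, and in this pair the outer 4-methoxyphenyl makes a large difference. The step between compound 2 and compound 3 cannot be read because both sit at the assay limit: the limit of > 1000 nM in this assay, at which 2 of the 3 values shown sit.

As far as these compounds go, whether a plain phenyl or an aminomethyl group on that aromatic carbon would recover activity remains open. From the compounds shown here alone, the true values of compound 2 and compound 3 also remain open.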